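A few compounds are considered here, and "the series" means these few. Any claim that something is new, unique, unknown or untested is made for them only; others in the source may bear on it.

Measured so far:
- compound 1, `C=C(C)[C@@H]1CC=C(C)/C(=N/NC(=O)Nc2nnc(-c3ccccc3)o2)C1`: in a functional assay on the whole organism (strain Swiss albino) with Mus musculus as the target, with a stated time of 4 h (a higher number here means that more compound is needed for the effect, a lower number that less compound is needed), compound 1 gives 300 mg/kg
- compound 2, `C=C(C)[C@@H]1CC=C(C)/C(=N/NC(=O)Nc2nnc(-c3ccc(OC)cc3)o2)C1`: in this assay compound 2 gives 300 mg/kg

Compound 2 stands level with compound 1 at the digits shown; the step of no change at the digits printed from compound 1 to compound 2 (within the scatter) lies within the scatter, so the two numbers carry no order between them. The series thus far contains a single step, and it says only that adding methoxy in place of hydrogen on the aromatic carbon left the minimum effective dose where it was.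

Compound 3, `C=C(C)[C@@H]1CC=C(C)/C(=N/NC(=O)Nc2nnc(-c3ccc(F)cc3)o2)C1`, is the next member. Its difference from compound 2 is fluoro in place of methoxy on an aromatic carbon. Among the compounds with values here, the one measured step that bears on this position, no change at the digits printed from compound 1 to compound 2 (within the scatter), was flat, and nothing measured here involves fluoro at all. Within the data shown here, with one flat step as the only guide, and no step of any size at this position to point in a direction, the expectation for this assay is no movement beyond the scatter. The step expected here is no change at the digits printed from compound 2 to compound 3 (within the scatter). Compound 3 is therefore estimated at 300 mg/kg, within a range from 150 mg/kg to 600 mg/kg.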

Compound 3, minimum effective dose: 300 mg/kg
Estimate against measurement, compound 3: no gap at the digits printed; measured number inside the range.
By their numbers in this assay, from the lowest: compounds 1, 2 and 3 (each within the scatter of the next).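

In this assay the change from 4-methoxyphenyl to 4-fluorophenyl gives no change at the digits printed from compound 2 to compound 3 (within the scatter), and fluoro in place of hydrogen on the aromatic carbon gives no change at the digits printed from compound 1 to compound 3 (within the scatter). The position, on an aromatic carbon of the six-membered aromatic ring and para to a large group, has now carried hydrogen, methoxy and fluoro with no order among the three readings, whereas the earlier pair covered only hydrogen and methoxy, so the flat reading now holds for a halogen as well as for an oxygen-linked group. No measurement of any property of these groups accompanies the result, and the flat reading stands here as an observation without an account of it.

Whether an amine, a carboxylic acid, a nitrile or a longer alkoxy chain at this position would move the reading in this assay stays open, since the three groups shown span only a narrow set of small substituents. Also open, as far as these compounds go, is whether the same exchanges would stay flat on other carbons of the aromatic ring, or whether changes in the shared core would shift the dose needed.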